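A few compounds are considered here, and "the series" means these few. Any claim that something is new, unique, unknown or untested is made for them only; others in the source may bear on it.

In an assay on isolated protein for inhibition of proto-oncogene tyrosine-protein kinase receptor Ret variant V804M (Homo sapiens), read by 33P incorporation, with stated times of 15 min and 40 min (on this read-out higher numbers stand for weaker inhibition and lower numbers for stronger inhibition), three analogues of one shared core have been measured. Compound 1 `O=C(Nc1ccc(Br)cc1)Nc1ccc(Nc2ncnc3c2OCCN3)cc1` gives 2350 nM, compound 2 `Cc1ccc(F)c(NC(=O)Nc2ccc(Nc3ncnc4c3OCCN4)cc2)c1` gives 5110 nM, and compound 3 `O=C(Nc1ccc(Nc2ncnc3c2OCCN3)cc1)Nc1cccc(-c2ccccc2)c1` gives 7590 nM. Compound 2 thus stands second highest of the three, within the scatter of compound 3 and separated beyond the scatter only from compound 1. Among the measured compounds shown here, the sole single-point step on record, a 2.2-fold higher number from compound 1 to compound 2 (0.34 log units; beyond the scatter), shows how far this assay moves when the aryl group on the amide-type nitrogen is exchanged. Compound 4 `O=C(Nc1ccc(Nc2ncnc3c2OCCN3)cc1)Nc1cccs1` carries thiophen-2-yl in place of 2-fluoro-5-methylphenyl on an amide-type nitrogen. The step expected in this assay is a 1.3-fold lower number from compound 2 to compound 4 (0.11 log units; within the scatter), because only a 2.2-fold higher number from compound 1 to compound 2 (0.34 log units; beyond the scatter) bears on the change and that step was modest. Compound 4 is therefore estimated at 4000 nM, with a range from 1500 nM to 12000 nM.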

Compound 4, half-maximal inhibitory concentration: 8640 nM
Compound 4: middle estimate off by 2.2-fold (0.33 log units), on the low side, within the range that was stated.
By their numbers in this assay, from the lowest: compound 1; then compounds 2, 3 and 4 (each within the scatter of the next).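

In this assay, thiophen-2-yl on the amide-type nitrogen stays level with the larger 2-fluoro-5-methylphenyl (a 1.7-fold higher number from compound 2 to compound 4 (0.23 log units; within the scatter)). Against 4-bromophenyl the same exchange lies beyond the scatter (a 3.7-fold higher number from compound 1 to compound 4 (0.57 log units; beyond the scatter)), so among these compounds the smaller five-membered ring brings no gain at this position. Nothing available explains why these numbers fall as they do. Still open, from the compounds shown here alone, is whether a non-aromatic group on the amide-type nitrogen, such as cyclohexyl, or an aromatic ring carrying an amine or a carboxylic acid, would give a lower number than compound 1 does.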